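The compounds below may be only part of what the source reports. "The series", "measured", "known", "first", "only" and "open" are said of these compounds alone.

Among the compounds with values here, in a functional assay on DU-145 cells (Homo sapiens) for cytotoxicity, read by MTT assay (on this read-out lower numbers stand for stronger inhibition and higher numbers for weaker inhibition), compound 2 (`CCCC(C)(O)CC(=O)O[C@H](CC=C(C)C)C1=CC(=O)c2c(O)ccc(O)c2C1=O`) gives 75000 nM, the higher of the two numbers so far, while compound 1 (`CCC(CO[C@H](CC=C(C)C)C1=CC(=O)c2c(O)ccc(O)c2C1=O)OC(C)=O`) gives 25400 nM. Compound 3 (`CCC(C)(O)CC(=O)O[C@H](CC=C(C)C)C1=CC(=O)c2c(O)ccc(O)c2C1=O`) has not yet been measured. It differs from compound 2 by hydrogen in place of methyl on a saturated chain carbon, three bonds along the chain from an oxygen on a saturated carbon, so that 1-hydroxy-1-methylbutyl becomes 1-hydroxy-1-methylpropyl. Within the data shown here, only one measured step bears on this change, and only loosely: a 3.0-fold higher number from compound 1 to compound 2 (0.47 log units; beyond the scatter), a modest step beyond the scatter, made by a different and larger change. Among the measured compounds shown here, no measured pair isolates the loss of this methyl. A small step at most is therefore expected in this assay, possibly none beyond the scatter, and any shift is expected to be towards a lower number. The estimated change is a 1.5-fold lower number from compound 2 to compound 3 (0.18 log units; within the scatter). The expected value for compound 3 is 50000 nM, with an estimated range from 22000 nM to 110000 nM.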

Compound 3, half-maximal inhibitory concentration: 16000 nM
Compound 3: the middle estimate sits 3.1-fold (0.49 log units) above what was measured, outside the stated range (below it).
By their numbers in this assay, from the lowest: compounds 3 and 1 (each within the scatter of the next); then compound 2.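

In this assay, the loss of a single methyl, turning 1-hydroxy-1-methylbutyl into 1-hydroxy-1-methylpropyl, gives a 4.7-fold lower number from compound 2 to compound 3 (0.67 log units; beyond the scatter) and so shows that this one carbon on the saturated chain is enough on its own to move the number beyond the scatter. Compound 2 had stood apart from compound 1, but the shorter chain removes that separation: a 1.6-fold lower number from compound 1 to compound 3 (0.20 log units; within the scatter) is a step within the scatter, so the 1-hydroxy-1-methylpropyl ester and the 2-acetoxybutyl ether cannot be told apart on this read-out. Nothing given here explains why this methyl matters.

On these data alone, only propyl and ethyl have been compared at this end of the chain, so it remains open whether a methyl there or a longer chain such as butyl would continue the same direction. As far as these compounds go, the effect of an amine or a carboxylic acid at this end, or of a hydrogen in place of the hydroxyl, also remains open.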